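Isopropylcarbamoyl in place of carbamoyl on the piperazine urea

This account rests on a few compounds, and the source may have more. Where it says the series, first, only, none or still open, it means among the compounds named here.

Compound 3 `COc1ccc(Cn2cc(CSC(=S)N3CCN(C(N)=O)CC3)nn2)cc1` is the carbamoyl member of the series. In a functional assay on SMMC-7721 cells (Homo sapiens) for cytotoxicity, read by MTT assay, with a stated time of 72 h (on this read-out lower numbers stand for stronger inhibition and higher numbers for weaker inhibition), compound 3 returns only a limit of the assay, > 128000 nM, and no number stands for it (the limit of > 128000 nM in this assay, at which 1 of the 3 values shown sits). Compound 4 `COc1ccc(Cn2cc(CSC(=S)N3CCN(C(=O)NC(C)C)CC3)nn2)cc1` differs from it by isopropyl in place of hydrogen on an amide-type nitrogen. Within the data shown here, the single measured step, a 1.2-fold lower number from compound 1 to compound 2 (0.08 log units; within the scatter), concerns the fluorophenyl and leaves the amide-type nitrogen untouched, so it gives no direct guide to this change. What the series does show is that both isopropylcarbamoyl members carry numbers: compound 1 `CC(C)NC(=O)N1CCN(C(=S)SCc2cn(Cc3ccccc3F)nn2)CC1` gives 7130 nM and compound 2 `CC(C)NC(=O)N1CCN(C(=S)SCc2cn(Cc3ccc(F)cc3)nn2)CC1` gives 5970 nM in this assay. Compound 4 is therefore expected to land near those two values. The expected step of an at least 18-fold lower number from compound 3 to compound 4 (1.26 log units; beyond the scatter) is a large drop from the limit. Compound 4 is estimated at 7000 nM, within 2500 nM to 30000 nM.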

Compound 4, half-maximal inhibitory concentration: > 128000 nM
Compound 4: no number, only a limit; the forecaster's own chance of this, stated with the estimate: 15%; at least 18-fold (1.26 log units) between middle value and limit.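

In this assay, compound 3 and compound 4 both stop at a limit, so the step from hydrogen to isopropyl on the amide-type nitrogen cannot be read: the limit of > 128000 nM in this assay, at which 2 of the 4 values shown sit.

The isopropylcarbamoyl group therefore does not by itself bring a measurable number in this series. Methoxy in place of fluoro gives an at least 21-fold higher number from compound 2 to compound 4 (1.33 log units; beyond the scatter), and 4-methoxyphenyl in place of 2-fluorophenyl gives an at least 17-fold higher number from compound 1 to compound 4 (1.25 log units; beyond the scatter).

The compounds shown leave open whether a carbamoyl member carrying fluoro gives a number. They also leave open how chloro or hydrogen in place of methoxy would read on the isopropylcarbamoyl series.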